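The source may report more compounds than this note shows. Statements on the series, on what has been measured and on what is new or still open speak of the compounds shown alone.

In an assay on cells for positive allosteric modulation of Cystic fibrosis transmembrane conductance regulator variant F508del (Homo sapiens), with stated times of 10 min and 7 s, in the presence of a further agent that is not named here (a lower number here means that less compound is needed, a higher number that more compound is needed for the effect), compound 1 `CC1(C)Cc2c(sc(NC(=O)c3ccccc3O)c2C(N)=O)C(C)(C)O1` gives 4 nM, while compound 2 `CC1(C)Cc2c(sc(NC(=O)c3nnc[nH]3)c2C(N)=O)C(C)(C)O1` gives 467 nM, the highest of the two numbers; the step of a 120-fold higher number from compound 1 to compound 2 (2.07 log units; beyond the scatter) is large. Compound 3 `CC1(C)Cc2c(sc(NC(=O)c3cn[nH]c3)c2C(N)=O)C(C)(C)O1` differs from compound 2 by 1H-pyrazol-4-yl in place of 4H-1,2,4-triazol-3-yl on a carbonyl carbon. No measured step concerns this exchange: the only step shown, a 120-fold higher number from compound 1 to compound 2 (2.07 log units; beyond the scatter), replaced a 2-hydroxyphenyl ring by the triazolyl ring and does not bear directly on swapping one five-membered ring for another. The step of a 1.2-fold lower number from compound 2 to compound 3 (0.07 log units; within the scatter) is therefore expected to stay within the scatter. Compound 3 is estimated at 400 nM, with a range from 100 nM to 1600 nM.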

Compound 3, half-maximal effective concentration: 125 nM
Beside the measured number, compound 3's estimate is 3.2-fold (0.51 log units) above it, and the stated range covers the measured number.
By their numbers in this assay, from the lowest: compound 1; then compound 3; then compound 2.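

Exchanging 4H-1,2,4-triazol-3-yl for 1H-pyrazol-4-yl on the carbonyl carbon gives a 3.7-fold lower number from compound 2 to compound 3 (0.57 log units; beyond the scatter) in this assay, so the choice between two five-membered aromatic rings matters at this position. Even so, 1H-pyrazol-4-yl recovers only part of the distance to 2-hydroxyphenyl, with a 31-fold higher number from compound 1 to compound 3 (1.49 log units; beyond the scatter). Nothing given here explains either step.

As far as these compounds go, whether a pyridine ring or a carboxylic acid on this carbonyl carbon would come closer to compound 1 remains open. So does whether the order of these three compounds holds in any other assay.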